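A few compounds are considered here, and "the series" means these few. Any claim that something is new, unique, unknown or untested is made for them only; others in the source may bear on it.

Of the compounds shown here, three sharing one core have been tested in a functional assay on MIA PaCa-2 cells (Homo sapiens) for inhibition, read by MTT assay; on this read-out higher numbers stand for weaker inhibition and lower numbers for stronger inhibition. Compound 1 `CN(C)C(=O)c1cc2cnc(Nc3ccccc3)nc2n1C1CCCC1` gives 54900 nM, compound 2 `O=C(Nc1ccccc1)c1cc2cnc(Nc3ccccc3)nc2n1C1CCCC1` gives 14000 nM, and compound 3 `O=C(Nc1ccccc1)c1cc2cnc(Nc3ccc(N4CCNCC4)cn3)nc2n1Cc1ccccc1` gives 3600 nM, the lowest of the three numbers. Compound 2 and compound 1 differ in one place: dimethylamino in place of anilino on a carbonyl carbon This change went with a 3.9-fold higher number from compound 2 to compound 1 (0.59 log units; beyond the scatter). The difference between the core of compound 2 and the core of compound 3 is not broken down here. Compound 4 `CN(C)C(=O)c1cc2cnc(Nc3ccc(N4CCNCC4)cn3)nc2n1Cc1ccccc1` has not yet been measured; it differs from compound 3 by the same change at the same kind of place: dimethylamino in place of anilino on a carbonyl carbon Because the same change gave a 3.9-fold higher number from compound 2 to compound 1 (0.59 log units; beyond the scatter), a step of similar size is expected, namely a 3.9-fold higher number from compound 3 to compound 4 (0.59 log units; beyond the scatter) in this assay. Compound 4 is therefore estimated at 14000 nM in this assay, most likely between 5000 nM and 40000 nM.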

Compound 4, half-maximal inhibitory concentration: 30400 nM
Compound 4: the middle estimate sits 2.2-fold (0.34 log units) below what was measured; the range from low to high includes it.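

In this assay, dimethylamino in place of anilino on the carbonyl carbon gave an 8.4-fold higher number from compound 3 to compound 4 (0.93 log units; beyond the scatter) on the core of compound 3, so the direction seen on the first core held on the second. Set side by side, the two steps cannot be told apart in size: the same change on two cores in this assay, a 3.9-fold higher number (0.59 log units; beyond the scatter) from compound 2 to compound 1 and an 8.4-fold higher number (0.93 log units; beyond the scatter) from compound 3 to compound 4, 2.2-fold (0.33 log units) apart, within the scatter of two such steps. This shows the change carrying over between these two cores only; two pairs make no rule for the series, and they do not show why the numbers rise.

Methylamino or benzylamino on the carbonyl carbon would separate the loss of the ring from the loss of the amide hydrogen, and the compounds shown leave that open. Also open, on these data alone, is whether a morpholine amide would follow the same step.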